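The compounds below may be only part of what the source reports. "The series", "measured", "known", "first", "only" and "open" are said of these compounds alone.

Compound 1, `Cn1c(SCC(=O)Nn2c(COc3ccc(Cl)cc3Cl)nc3ccccc3c2=O)nc(-c2ccc(Cl)cc2)c(C#N)c1=O`, gives 73.7% in a functional assay on the whole organism (strain albino) for inhibition, with Rattus norvegicus as the target, read by paw edema, with stated times of 1 h and 2 h, at a dose of 100 mg/kg by the oral route; a higher number here means more inhibition at the dose given (going by the name of the read-out), a lower number less inhibition. Compound 2, `Cn1c(SCC(=O)Nn2c(COc3ccc(Cl)cc3Cl)nc3ccccc3c2=O)nc(-c2ccc(O)cc2)c(C#N)c1=O`, gives 86% in this assay. Compound 3, `N#Cc1c(Cl)nc(SCC(=O)Nn2c(COc3ccc(Cl)cc3Cl)nc3ccccc3c2=O)nc1-c1ccc(Cl)cc1`, gives 68.4% in this assay.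

Compound 1 and compound 2 share one core and differ in a single place: hydroxy in place of chloro on an aromatic carbon. This change raises the read-out in this assay by a number 12.3 percentage points higher from compound 1 to compound 2 (beyond the scatter).

Compound 3 carries a different core. How that core differs from the core of compound 1 is not broken down here; the number for compound 3 lies within the usual scatter of the number for compound 1, while the number for compound 2 lies beyond it.

Compound 4, `N#Cc1c(Cl)nc(SCC(=O)Nn2c(COc3ccc(Cl)cc3Cl)nc3ccccc3c2=O)nc1-c1ccc(O)cc1`, has not yet been measured. It stands to compound 3 as compound 2 stands to compound 1, since the difference between them is hydroxy in place of chloro on an aromatic carbon, and the surroundings of the change are described in the same words for both pairs. Within the data shown here, the same change is therefore made on a second core, and the only guide to its size is the one measured instance.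

On that basis, the step in this assay from compound 3 to compound 4 is expected to be about a number 11.6 percentage points higher from compound 3 to compound 4 (beyond the scatter), resting on the step of a number 12.3 percentage points higher from compound 1 to compound 2 (beyond the scatter) seen in the first pair. Compound 4 is accordingly estimated to give about 80% in this assay, with a likely range from 68% to 92%.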

Compound 4, a percentage reported as inhibition, in the whole organism at one dose (the size of the read-out at that dose, not a potency): 73.7%
The estimate for compound 4 lay 6.3 percentage points above the measured number, and the stated range covers the measured number.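

On the second core, replacing 4-chlorophenyl with 4-hydroxyphenyl gives, in this assay, a number 5.3 percentage points higher from compound 3 to compound 4 (within the scatter), so the two numbers of this pair cannot be told apart. Set beside the first pair, the step is beyond the scatter on one core and within it on the other, yet the gap between the two steps is no larger than repeated measurements would allow: the same change on two cores in this assay, a number 12.3 percentage points higher (beyond the scatter) from compound 1 to compound 2 and a number 5.3 percentage points higher (within the scatter) from compound 3 to compound 4, 7 percentage points apart, within the scatter of two such steps. This shows only that the data give no ground to call the two steps different; with just two pairs, it does not show that the step has the same size on both cores, or that it would hold on any further core.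

The compounds shown leave open whether another group at the same place, such as a methoxy group, an amine or a carboxylic acid, would read like hydroxy or like chloro on either core. They also leave open whether a longer chain in place of the methyl group on the core of compound 1 would alter the size of the step.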